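A Fluoro Swap on the Benzyl Group of Compound 1

This account rests on a few compounds, and the source may have more. Where it says the series, first, only, none or still open, it means among the compounds named here.

In an ADME assay on HUVEC cells (Homo sapiens) for cytotoxicity, read by MTT assay, with a stated time of 48 h (a higher number here means a weaker inhibitor, a lower number a stronger inhibitor), compound 1 `Cc1c(Cc2ccccc2)c(=O)oc2cc(OCCOc3no[n+]([O-])c3S(=O)(=O)c3ccccc3)ccc12` gives 440 nM and compound 2 `COc1cc(OCCOc2no[n+]([O-])c2S(=O)(=O)c2ccccc2)ccc1C(=O)/C=C/c1ccc(F)cc1` gives 360 nM with the two values within the scatter of each other. Compound 3 `Cc1c(Cc2ccc(F)cc2)c(=O)oc2cc(OCCOc3no[n+]([O-])c3S(=O)(=O)c3ccccc3)ccc12` differs from compound 1 by one change fluoro in place of hydrogen on an aromatic carbon that turns benzyl into 4-fluorobenzyl: fluoro in place of hydrogen on an aromatic carbon. For the measured compounds named here, no measured pair shows this change. The step expected in this assay is none beyond the scatter, with no direction favoured. The estimated step of a 1.1-fold lower number from compound 1 to compound 3 (0.04 log units; within the scatter) is accordingly small. In this assay compound 3 is expected at 400 nM with an estimated range from 180 nM to 850 nM around that middle.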

Compound 3, half-maximal inhibitory concentration: 270 nM
Compound 3: middle estimate off by 1.5-fold (0.17 log units), on the high side; low and high end bracket the measured number.
By their numbers in this assay, from the lowest: compounds 3, 2 and 1 (each within the scatter of the next).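

For the compounds shown here, compound 3 gives the first direct reading at this position: in this assay, fluoro in place of hydrogen on an aromatic carbon, turning benzyl into 4-fluorobenzyl, gives a 1.6-fold lower number from compound 1 to compound 3 (0.21 log units; within the scatter). The core of compound 1 therefore accepts this single change at the para position of the benzyl ring without a step beyond the scatter. Nothing measured here bears on a cause for this result.

The compounds shown leave open whether an amine, a carboxylic acid or a longer chain in place of the fluoro would give a step beyond the scatter in this assay.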